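The compounds below may be only part of what the source reports. "The series", "measured", "known", "first", "only" and "open" are said of these compounds alone.

Three compounds have been measured in a functional assay on cells (Lymphocyte, Homo sapiens), read by trypan blue exclusion, with a stated time of 16 h, tested at 0.5 uM; a lower number here means a weaker effect, a higher number a stronger effect of the compound at the concentration tested:

compound 1, `CCCCCCCCCCc1c(C)c(N(C)C)nc(C)c1O`: 87%
compound 2, `Cc1c(N(C)C)nc(CCCCCCCCCCO)c(O)c1C`: 36%
compound 3, `CCCCCCCCCCCCCCCCCCCc1c(C)c(N(C)C)nc(C)c1O`: 8%

Of these three numbers, compound 2 stands second highest; compound 1 is higher by a margin beyond the scatter, and compound 3 is lower, also beyond the scatter.

Compound 4, `CCCCCCCCCCCCCCCCc1nc(N(C)C)c(C)c(C)c1O`, is not yet measured. Compared with compound 2 the change is hexyl in place of hydroxy on a saturated chain carbon, ten or more bonds along the chain from an aromatic carbon. Going by the values given here, the one measured step that resembles it is the lengthening of the chain from compound 1 to compound 3, where the number fell by a number 79 percentage points lower from compound 1 to compound 3 (beyond the scatter). Compound 4 carries a chain shorter than that of compound 3 but longer than that of compound 1, and it loses the hydroxy that compound 2 carries at the end of its chain. From this, a drop in this assay is expected, smaller than the step from compound 1 to compound 3 but beyond the scatter. For compound 4 the estimated value is 15%, within a range from 3% to 40%. This estimate amounts to an expected step of a number 21 percentage points lower from compound 2 to compound 4 (beyond the scatter).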

Compound 4, a percentage reported as activity, at one concentration (the size of the read-out at that concentration, not a potency): 78%
Estimate against measurement, compound 4: 63 percentage points below; the whole stated range lies below it.
By their numbers in this assay, from the lowest: compound 3; then compound 2; then compounds 4 and 1 (each within the scatter of the next).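

In this assay hexyl in place of hydroxy on a saturated chain carbon, ten or more bonds along the chain from an aromatic carbon, gives a number 42 percentage points higher from compound 2 to compound 4 (beyond the scatter) and so shows that the far end of this chain matters for the read-out. This large rise runs opposite to a number 79 percentage points lower from compound 1 to compound 3 (beyond the scatter) even though both changes add carbon to a chain, so among these compounds a bigger chain does not always mean a lower number. No measurement shown explains the rise.

The compounds shown leave open whether the gain comes from losing the hydroxy or from gaining the hexyl. A chain ending in an amine or a carboxylic acid, or a longer chain still ending in hydroxy, would help to separate the two.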